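A pyridinone in place of a chloropyridine: expected cytotoxicity

The compounds below may be only part of what the source reports. "The series", "measured", "known", "first", "only" and "open" are said of these compounds alone.

Measured compounds:
compound 1, `O=S(=O)(Cc1nc(-c2ccnc(Cl)c2)c2sccc2n1)c1cccc(Cl)c1`, 63000 nM
compound 2, `COc1ccc(-c2nc(C(F)(F)S(=O)(=O)c3cccc(Cl)c3)nc3ccsc23)cn1`, > 50000 nM
compound 3, `COc1ccc(-c2nc(CSc3ccc(F)cc3F)nc3ccsc23)cn1`, > 50000 nM

Going by the values given here, in an ADME assay on cells (Homo sapiens) for cytotoxicity, read by resazurin assay, with a stated time of 5 days (on this read-out higher numbers stand for lower toxicity in this test and lower numbers for higher toxicity in this test), compound 1 gives 63000 nM, the only actual number among the three measured compounds. Compound 2 reaches only a limit of the assay in this assay, > 50000 nM. Compound 3 also ends at a limit in this assay, > 50000 nM. Among the compounds with values here, two of the three values therefore sit at the limit of > 50000 nM in this assay, at which 2 of the 3 values shown sit, and compound 1 stands close to it with its single number.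

Compound 4, `O=c1ccc(-c2nc(CS(=O)(=O)c3cccc(Cl)c3)nc3ccsc23)c[nH]1`, has not yet been measured in this assay. It differs from compound 1 in one place: a group of 7 heavy atoms (5 carbon, 1 nitrogen, 1 oxygen; one six-membered aromatic ring with 1 hetero atom) in place of a group of 7 heavy atoms (5 carbon, 1 nitrogen, 1 chlorine; one six-membered aromatic ring with 1 hetero atom), on an aromatic carbon.

Within the data shown here, no step between two measured compounds is available, so there is no measured change to lean on. Compound 4 carries a group that brings one hydrogen-bond donor and one hydrogen-bond acceptor where compound 1 carries none and one; the three measured compounds all lie at or near the limit, so the step from compound 1 to compound 4 is expected to be none beyond the usual scatter, a 1.2-fold higher number from compound 1 to compound 4 (0.08 log units; within the scatter). For compound 4 the half-maximal cytotoxic concentration is estimated at 75000 nM, within the range 30000 nM to 200000 nM.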

Compound 4, half-maximal cytotoxic concentration: > 50000 nM
Compound 4: a limit, no number (the forecaster's own chance of this, stated with the estimate: 55%); the middle value is on the limit's open side.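

In this assay compound 4 gives a limit and not a number, > 50000 nM. Going by these compounds alone, no step from compound 1 to compound 4 can therefore be read. The compounds shown leave open whether replacing the 2-chloropyridin-4-yl group changes the half-maximal cytotoxic concentration at all, and by how much.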